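The compounds below may be only part of what the source reports. "The series", "measured", "known", "first", "only" and "open" are said of these compounds alone.

Measured so far:
- compound 1 `CC(C)(C)OC(=O)Nc1ncc(C(Oc2cccc(C#N)c2)c2ccc(Cl)cc2)s1`: > 50000 nM
- compound 2 `COc1ccc(Br)c(COC(c2ccccc2)c2cnc(NC(=O)c3cccs3)s2)c1`: "not toxic" (no number reported)
- compound 3 `COCCNc1ncc(C(Oc2ccc3cc(Br)ccc3c2)c2ccc(Cl)cc2)s1`: "not toxic" (no number reported)

In an ADME assay on HepG2 2.2.15 cells (Homo sapiens) for cytotoxicity (on this read-out higher numbers stand for lower toxicity in this test and lower numbers for higher toxicity in this test), compound 3 gives "not toxic" (no number reported), an entry without a single number. For compound 1 the entry > 50000 nM is a limit of the assay, not a measured number. Compound 2 is likewise recorded without a number, so compound 3 cannot be placed on a scale: of the three entries shown, one is a limit of > 50000 nM in this assay, at which 1 of the 3 values shown sits, and the other two carry no number at all. Among the measured compounds shown here, no step between two measured compounds that differ in one place is available here.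

Compound 4 `CCCCCC(=O)Nc1ncc(C(Oc2ccc3cc(Br)ccc3c2)c2ccc(Cl)cc2)s1` has not been measured. It differs from compound 3 in one place: pentylcarbonyl in place of 2-methoxyethyl on a nitrogen on an aromatic ring. In this assay the two compounds beside compound 3 give either a limit or no number, and nothing among them shows a change of toxicity with a change of structure. For the step from compound 3 to compound 4 no shift beyond the usual scatter is therefore expected in this assay, in either direction. Compound 4 is expected to give about 50000 nM, within a range from 20000 nM to 100000 nM, most likely again reported only as a limit.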

Compound 4, half-maximal cytotoxic concentration: > 50000 nM
Compound 4 was reported as a limit; the forecaster's own chance of this, stated with the estimate: 70%; the middle value lies on the limit itself.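

In this assay compound 4 gives > 50000 nM, which is a limit of the assay and not a number. Compound 3 gives "not toxic" (no number reported), so no step can be read from compound 3 to compound 4. The compounds shown leave open whether exchanging 2-methoxyethyl for pentylcarbonyl changes toxicity in this assay at all, and at what concentration, if any, these compounds harm the cells.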